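Pentyl to cyclopropyl on the shared core

A few compounds are considered here, and "the series" means these few. Any claim that something is new, unique, unknown or untested is made for them only; others in the source may bear on it.

Compound 2 `CCCCCc1cn(C(c2ccccc2)c2cc3cc(Br)ccc3nc2OC)nn1` stands lowest of the three measured compounds in an ADME assay on HeLa cells (Homo sapiens) for cytotoxicity, read by sulforhodamine B assay, with a stated time of 48 h, tested at 10 uM (on this read-out higher numbers stand for more inhibition at the one concentration tested (going by the name of the read-out) and lower numbers for less inhibition), at -9.81%. Compound 1 `COc1nc2ccc(Br)cc2cc1C(c1ccccc1)n1cc(-c2ccccc2F)nn1` gives 14.1% and compound 3 `COc1nc2ccc(Br)cc2cc1C(c1ccccc1)n1cc(-c2cccc(F)c2)nn1` gives 9.04%. The steps touching compound 2 are a number 18.9 percentage points higher from compound 2 to compound 3 (beyond the scatter) and a number 23.9 percentage points lower from compound 1 to compound 2 (beyond the scatter); between the two aryl groups the change is only a number 5.1 percentage points lower from compound 1 to compound 3 (within the scatter). Compound 4 `COc1nc2ccc(Br)cc2cc1C(c1ccccc1)n1cc(C2CC2)nn1` differs from compound 2 by cyclopropyl in place of pentyl on an aromatic carbon, a ring entering where the chain left. For the measured compounds named here, no measured step exchanges one non-aromatic group for another; the two steps that bear on this change both move away from pentyl and upward. A smaller shift is expected here, a number 9.8 percentage points higher from compound 2 to compound 4 (within the scatter), likely within the scatter. Compound 4 is therefore estimated at 0%, with a range from -15% to 15%.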

Compound 4, a percentage reported as inhibition, at one concentration (the size of the read-out at that concentration, not a potency): -5.84%
The estimate for compound 4 lay 5.8 percentage points above the measured number; measured number inside the range.
By their numbers in this assay, from the lowest: compounds 2 and 4 (each within the scatter of the next); then compounds 3 and 1 (each within the scatter of the next).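

In this assay swapping the pentyl chain for the cyclopropyl ring at this aromatic carbon changes little (a number 4 percentage points higher from compound 2 to compound 4 (within the scatter)). Cyclopropyl instead stands apart from both fluorophenyl groups (a number 14.9 percentage points lower from compound 3 to compound 4 (beyond the scatter)) (a number 19.9 percentage points lower from compound 1 to compound 4 (beyond the scatter)), so among these four compounds the two non-aromatic groups fall on one side and the two aryl groups on the other. No measurement given here accounts for this split.

Still open, on these data alone, is whether an unsubstituted phenyl matches the fluorophenyl compounds. Also open, as far as these compounds go, is how an amine or a carboxylic acid on this carbon would read.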